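A few compounds are considered here, and "the series" means these few. Any claim that something is new, unique, unknown or untested is made for them only; others in the source may bear on it.

Of the compounds shown here, three share a core and have been tested in a functional assay on HT-29 cells (Homo sapiens) for cytotoxicity, read by MTT assay, with a stated time of 48 h; a higher number here means a weaker inhibitor, a lower number a stronger inhibitor. Compound 1, `COC(=O)/C=C/c1ccc2c(c1)C(=O)C(=O)N2Cc1ccc(Cl)c(Cl)c1`, gives 210 nM in this assay. For the measured compounds named here, compound 3, `COC(=O)/C=C/c1ccc2c(c1)C(O)C(=O)N2Cc1ccc(OC)cc1`, gives 320 nM, a number within the usual scatter of the one for compound 1, so the two cannot be told apart. Compound 2, `CCCCOC(=O)/C=C/c1ccc2c(c1)C(=O)C(=O)N2Cc1ccc(Br)cc1`, gives 600 nM, a higher number that lies beyond the scatter, so it is the weaker inhibitor of the pair. Compound 4, `COC(=O)/C=C/c1ccc2c(c1)C(=O)C(=O)N2C`, has not yet been measured. It differs from compound 1 in one place: hydrogen in place of 3,4-dichlorophenyl on a saturated chain carbon bound to an amide-type nitrogen in a ring. A group of this size has not been removed elsewhere among these compounds, so the step is expected from the structures alone. It is expected to raise the number beyond the scatter, a 7.1-fold higher number from compound 1 to compound 4 (0.85 log units; beyond the scatter). Compound 4 is estimated at 1500 nM, within 400 nM to 6000 nM.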

Compound 4, half-maximal inhibitory concentration: 300 nM
Compound 4: middle estimate off by 5.0-fold (0.70 log units), on the high side; the measured number lies below the stated range.
By their numbers in this assay, from the lowest: compounds 1, 4, 3 and 2 (each within the scatter of the next, the first and the last beyond it).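

In this assay, hydrogen in place of 3,4-dichlorophenyl on a saturated chain carbon bound to an amide-type nitrogen in a ring gives no change that can be told apart (a 1.4-fold higher number from compound 1 to compound 4 (0.15 log units; within the scatter)). At this position, then, the whole aromatic ring can go with no measurable change in this cytotoxicity read-out. Nothing measured here explains why. Still open, as far as these compounds go, is what other groups on this carbon would do, such as an amine, a carboxylic acid or a longer chain. Also open, from the compounds shown here alone, is whether a smaller ring-bearing group would behave like either compound.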